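Moving the Fluorine Around a Phenyl Ring

The source may hold more compounds than are shown below. What is called first, only, known or untested is meant among the compounds shown, and "the series" means these compounds.

Three compounds have been measured in a functional assay on DU-145 cells (Homo sapiens) for inhibition; a higher number here means a weaker inhibitor, a lower number a stronger inhibitor:
Compound 1, `Oc1ccc(-c2cc(-c3ccc(F)cc3)cc(-c3ccccc3O)n2)cc1`: > 50000 nM, which is a limit of the assay rather than a number.
Compound 2, `Oc1ccc(-c2cc(-c3ccccc3F)cc(-c3ccc(O)cc3)n2)cc1`: 7780 nM.
Compound 3, `Oc1ccc(-c2cc(-c3cccc(F)c3)cc(-c3ccc(O)cc3)n2)cc1`: 9290 nM.

Compound 3 and compound 2 sit within the scatter of each other, and the third value is only a limit. Within the data shown here, the step of a 1.2-fold higher number from compound 2 to compound 3 (0.08 log units; within the scatter) is the one measured step that moves the fluorine on its ring, and it stays within the scatter. Compound 4, `Oc1ccc(-c2cc(-c3ccc(F)cc3)cc(-c3ccc(O)cc3)n2)cc1`, differs from compound 3 by 4-fluorophenyl in place of 3-fluorophenyl on an aromatic carbon. Compound 1 also carries a 4-fluorophenyl group, but it differs from compound 4 in a second place too, so its limit is not a guide. Because a 1.2-fold higher number from compound 2 to compound 3 (0.08 log units; within the scatter) stays within the scatter, no change beyond the scatter is expected in this assay. The expected step is a 1.1-fold higher number from compound 3 to compound 4 (0.03 log units; within the scatter). Compound 4 is therefore estimated at 10000 nM, with a range from 4000 nM to 30000 nM.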

Compound 4, half-maximal inhibitory concentration: 6030 nM
Beside the measured number, compound 4's estimate is 1.7-fold (0.22 log units) above it; low and high end bracket the measured number.
By their numbers in this assay, from the lowest: compounds 4, 2 and 3 (each within the scatter of the next). At a limit, above all of these: compound 1.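

All three fluorine positions on this ring now sit within the scatter of one another (a 1.5-fold lower number from compound 3 to compound 4 (0.19 log units; within the scatter); a 1.3-fold lower number from compound 2 to compound 4 (0.11 log units; within the scatter)), so moving the fluorine around the ring shows no measurable effect on the number. Among these compounds, the only step beyond the scatter moves a hydroxyl instead, with 4-hydroxyphenyl in place of 2-hydroxyphenyl (an at least 8.2-fold lower number from compound 1 to compound 4 (0.91 log units; beyond the scatter)). The value of compound 1 behind that step is a limit, not a number: (the limit of > 50000 nM in this assay, at which 1 of the 4 values shown sits).

From the compounds shown here alone, whether a ring carrying an amine or a carboxylic acid in place of the fluorine would shift the number at this position remains open.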